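Swapping one fused ring attachment, cytotoxicity expected unchanged

The compounds below may be only part of what the source reports. "The series", "measured", "known", "first", "only" and "open" are said of these compounds alone.

Three compounds have been examined in an ADME assay on HUVEC cells (Homo sapiens) for cytotoxicity, read by MTT assay, with a stated time of 48 h; a higher number here means that more compound is tolerated, a lower number that less compound is tolerated. Compound 1 `O=C(N[C@H]1C[C@@H](C(=O)NO)N(S(=O)(=O)c2ccc(Oc3ccccc3)cc2)C1)c1ccc2no[n+]([O-])c2c1` gives 32500 nM, and compound 2 `O=C(N[C@H]1C[C@@H](C(=O)NO)N(S(=O)(=O)c2ccc(Oc3ccccc3)cc2)C1)c1cccc2no[n+]([O-])c12` gives 37200 nM; the step of a 1.1-fold higher number from compound 1 to compound 2 (0.06 log units; within the scatter) shows that these two readings are not separable from each other. Compound 3 `COc1ccc(/C=C/C(=O)N2C[C@@H](NC(=O)c3ccc4no[n+]([O-])c4c3)C[C@H]2C(=O)NO)cc1OC`, which differs from both elsewhere in the molecule, gives 36300 nM. Among the three numbers compound 3 stands second highest, yet the nearest reading, that of compound 2, and the furthest, that of compound 1, both lie within the scatter of it. In practice all three compounds are tolerated to the same degree.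

Compound 4 `COc1ccc(/C=C/C(=O)N2C[C@@H](NC(=O)c3cccc4no[n+]([O-])c34)C[C@H]2C(=O)NO)cc1OC` has not yet been measured. It differs from compound 3 in one place only: a group of 10 heavy atoms (6 carbon, 2 nitrogen, 2 oxygen; one five-membered aromatic ring with 3 hetero atoms, one six-membered aromatic ring of carbon only) in place of a group of 10 heavy atoms (6 carbon, 2 nitrogen, 2 oxygen; one five-membered aromatic ring with 3 hetero atoms, one six-membered aromatic ring of carbon only), on a carbonyl carbon. The very same exchange has been seen once already, in the step of a 1.1-fold higher number from compound 1 to compound 2 (0.06 log units; within the scatter), which stayed within the scatter. For the measured compounds named here, that single precedent is the only evidence bearing on the question, and it points to no movement beyond the usual noise. Compound 4 is therefore expected to give a number close to that of compound 3, with an estimated step of a 1.0-fold higher number from compound 3 to compound 4 (0.01 log units; within the scatter). The estimate for compound 4 in this assay is 37000 nM, with a range from 21000 nM to 65000 nM.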

Compound 4, half-maximal cytotoxic concentration: 42300 nM
For compound 4 the middle estimate is 1.1-fold (0.06 log units) below the measured one; the range from low to high includes it.
By their numbers in this assay, from the lowest: compounds 1, 3, 2 and 4 (each within the scatter of the next).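

The exchange of one fused-ring group for another made of the same atoms, joined differently, has now been read on a second core. On the carbonyl carbon whose other neighbour is an amide-type nitrogen, it gives a 1.2-fold higher number from compound 3 to compound 4 (0.07 log units; within the scatter) in this assay. A single pair could not show whether the lack of movement belonged to the core of compound 1 alone, but the exchange now leaves the reading inside the usual noise on both cores, and the two steps agree closely with each other: the same change on two cores in this assay, a 1.1-fold higher number (0.06 log units; within the scatter) from compound 1 to compound 2 and a 1.2-fold higher number (0.07 log units; within the scatter) from compound 3 to compound 4, 1.0-fold (0.01 log units) apart, within the scatter of two such steps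

What remains open is how far this tolerance for change at the carbonyl carbon extends, since the compounds shown carry only these two closely related fused-ring groups there and neither of them differs from the other in its counted atoms, donors or acceptors. A group of a different kind in the same place, such as a carboxylic acid, an amine or a longer alkyl chain, could still move the number, and these compounds give no reading of that.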